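A Saturated Chain in Place of an Unsaturated One

The source may report more compounds than this note shows. Statements on the series, on what has been measured and on what is new or still open speak of the compounds shown alone.

Of the compounds shown here, two have so far been measured in a functional assay on K562 cells (Homo sapiens) for inhibition, read by fluorescence, with a stated time of 72 h; a higher number here means a weaker inhibitor of growth, a lower number a stronger inhibitor of growth. Compound 1 (`CC(C)CCn1cnc2c(Nc3ccc(Cl)cc3)nc(N[C@H]3CC[C@H](N)CC3)nc21`) gives 1800 nM, and compound 2 (`CC(C)=CCn1cnc2c(Nc3cccc(Cl)c3)nc(N[C@H]3CC[C@H](N)CC3)nc21`) gives 3500 nM. These two values lie within the scatter of each other, so compound 2 stands level with compound 1 on the numbers shown.

Compound 3 (`CC(C)CCn1cnc2c(Nc3cccc(Cl)c3)nc(N[C@H]3CC[C@H](N)CC3)nc21`) differs from compound 2 in one place: isobutyl in place of 2-methylprop-1-en-1-yl on a saturated chain carbon bound to an aromatic nitrogen. The double bond outside aromatic rings is lost.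

For the measured compounds named here, no measured pair shows what this change does, so only a small shift is expected. The estimated step, a 1.3-fold lower number from compound 2 to compound 3 (0.13 log units; within the scatter), points towards a lower number but is expected to stay within the scatter. For compound 3 the expected value is 2600 nM, with an estimated range from 1200 nM to 5500 nM.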

Compound 3, concentration for 50% growth inhibition: 1500 nM
Compound 3: the middle estimate sits 1.7-fold (0.24 log units) above what was measured, and the stated range covers the measured number.
By their numbers in this assay, from the lowest: compounds 3, 1 and 2 (each within the scatter of the next, the first and the last beyond it).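

In this assay, for the compounds shown here, the step of a 2.3-fold lower number from compound 2 to compound 3 (0.37 log units; beyond the scatter) gives the first reading at this position, and it is a modest one: with isobutyl in place of 2-methylprop-1-en-1-yl on a saturated chain carbon bound to an aromatic nitrogen, the loss of the double bond outside aromatic rings is followed by a shift beyond the scatter. With the isobutyl group held constant, 3-chlorophenyl in place of 4-chlorophenyl gives a 1.2-fold lower number from compound 1 to compound 3 (0.08 log units; within the scatter) and so leaves compound 1 and compound 3 level. The data shown offer no independent measurement that would account for the step at the chain.

The compounds shown leave open how a longer chain, a benzyl group or a chain ending in an amine would compare at this place. They also leave open whether the same change of chain would give a similar step alongside 4-chlorophenyl.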